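This account rests on a few compounds, and the source may have more. Where it says the series, first, only, none or still open, it means among the compounds named here.

Notes on the series. The shared core is held constant across the set; the variation sits on the phenoxy substituent attached to the six-membered ring and on the neighbouring alkoxy group. Compound 1 `CC[C@@H]1/C=C(\C)C[C@H](C)C[C@H](OC)[C@H]2O[C@@](O)(C(=O)C(=O)N3CCCC[C@H]3C(=O)O[C@H](/C(C)=C/[C@@H]3CC[C@@H](Oc4ccccc4)[C@H](OC)C3)[C@H](C)[C@@H](O)CC1=O)[C@H](C)C[C@@H]2OC` gives 5.4 nM in a functional assay on cells for inhibition, with Murine T-cell line (Mus musculus) as the target; a higher number here means a weaker inhibitor, a lower number a stronger inhibitor. Compound 2 `CC[C@@H]1/C=C(\C)C[C@H](C)C[C@H](OC)[C@H]2O[C@@](O)(C(=O)C(=O)N3CCCC[C@H]3C(=O)O[C@H](/C(C)=C/[C@@H]3CC[C@@H](Oc4ccc(C)cc4)[C@H](O)C3)[C@H](C)[C@@H](O)CC1=O)[C@H](C)C[C@@H]2OC` carries a hydroxyl rather than methoxy and a methyl group on the aromatic ring, and in this assay compound 2 gives 6 nM; the values of compound 1 and compound 2 sit within the scatter of each other. Compound 3 `CC[C@@H]1/C=C(\C)C[C@H](C)C[C@H](OC)[C@H]2O[C@@](O)(C(=O)C(=O)N3CCCC[C@H]3C(=O)O[C@H](/C(C)=C/[C@@H]3CC[C@@H](Oc4ccc(SC)cc4)[C@H](OC)C3)[C@H](C)[C@@H](O)CC1=O)[C@H](C)C[C@@H]2OC` gives 2.6 nM in this assay, the lowest of the three numbers, with compound 1 nearest and compound 2 furthest. Going by the values given here, the single measured step that reaches compound 3 is a 2.1-fold lower number from compound 1 to compound 3 (0.32 log units; beyond the scatter), a modest change beyond the scatter.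

Compound 4 `CC[C@@H]1/C=C(\C)C[C@H](C)C[C@H](OC)[C@H]2O[C@@](O)(C(=O)C(=O)N3CCCC[C@H]3C(=O)O[C@H](/C(C)=C/[C@@H]3CC[C@@H](Oc4ccc(C)cc4)[C@H](OC)C3)[C@H](C)[C@@H](O)CC1=O)[C@H](C)C[C@@H]2OC` differs from compound 3 by methyl in place of methylsulfanyl on an aromatic carbon. Among the compounds with values here, no measured pair isolates methyl against methylsulfanyl on this ring, and compound 2 differs from compound 4 at a second place, so it offers no clean step. Within the data shown here, the only bearing step is the methylsulfanyl-for-hydrogen change from compound 1 to compound 3, and a methyl is expected to recover part of that difference rather than all of it. Compound 4 is therefore expected to show a small upward step, a 1.6-fold higher number from compound 3 to compound 4 (0.21 log units; within the scatter), within or near the scatter. The estimate for compound 4 in this assay is 4.2 nM, with a range from 2.3 nM to 7.8 nM.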

Compound 4, half-maximal inhibitory concentration: 2.7 nM
Beside the measured number, compound 4's estimate is 1.6-fold (0.19 log units) above it; the measured number falls inside the stated range.
By their numbers in this assay, from the lowest: compounds 3, 4, 1 and 2 (each within the scatter of the next, the first and the last beyond it).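

Working notes on compound 4. In this assay, the step of a 1.0-fold higher number from compound 3 to compound 4 (0.02 log units; within the scatter) shows that methyl and methylsulfanyl on this aromatic carbon, para to a large group, cannot be told apart. Measured against the unsubstituted phenoxy compound, the step of a 2.0-fold lower number from compound 1 to compound 4 (0.30 log units; within the scatter) stays within the scatter, while the methylsulfanyl step a 2.1-fold lower number from compound 1 to compound 3 (0.32 log units; beyond the scatter) lies just beyond it, so the two substituents differ in how their steps from hydrogen are classed even though their own values cannot be separated. Going by these compounds alone, the first clean reading at the neighbouring oxygen, a 2.2-fold lower number from compound 2 to compound 4 (0.35 log units; beyond the scatter) for methyl in place of hydrogen, lies beyond the scatter and is modest, and no measurement here bears on the reason for any of these steps.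

From the compounds shown here alone, it remains open whether other groups at this aromatic carbon, such as a chlorine, an amine, a carboxylic acid or a longer alkyl chain, would also leave the number unchanged. Going by these compounds, the hydroxyl-to-methoxy step is also read only with the 4-methylphenoxy group in place, so its size with the unsubstituted phenoxy or the 4-(methylsulfanyl)phenoxy group remains open.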